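Working notes: exchanging the bicyclic group on compound 3

The compounds below may be only part of what the source reports. "The series", "measured", "known", "first", "only" and "open" are said of these compounds alone.

Measured in a functional assay on COLO 205 cells (Homo sapiens) for antiproliferative activity, read by MTT assay, with a stated time of 68 h; a higher number here means a weaker inhibitor, a lower number a stronger inhibitor:
- compound 1 `O=S(=O)(Nc1ccc(F)c(C#Cc2cnc3[nH]ncc3c2)c1F)c1ccccc1`: 2100 nM
- compound 2 `O=S(=O)(Nc1ccc(F)c(C#Cc2cnc3[nH]ncc3c2)c1F)c1cccc(F)c1`: 758 nM
- compound 3 `O=S(=O)(Nc1ccc(F)c(C#Cc2ccc3[nH]ncc3c2)c1F)c1cccnc1`: > 10000 nM

The entry for compound 3 is a limit of the assay and not a number, so any step from it has no exact size.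

Compound 4 `Cc1n[nH]c2ncc(C#Cc3c(F)ccc(NS(=O)(=O)c4cccnc4)c3F)cc12` differs from compound 3 on a triple-bonded carbon, where 1H-indazol-5-yl leaves: a group of 10 heavy atoms (7 carbon, 3 nitrogen; one five-membered aromatic ring with 2 hetero atoms, one six-membered aromatic ring with 1 hetero atom) in place of a group of 9 heavy atoms (7 carbon, 2 nitrogen; one five-membered aromatic ring with 2 hetero atoms, one six-membered aromatic ring of carbon only), on a triple-bonded carbon.

Within the data shown here, no measured step covers this exchange. The only one available is a 2.8-fold lower number from compound 1 to compound 2 (0.44 log units; beyond the scatter), a fluoro in place of hydrogen on an aromatic carbon, which is a different change and gives only a rough sense of scale in this series.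

A lower number is expected in this assay, resting on the series values, where compound 1 gives 2100 nM and compound 2 gives 758 nM. This expectation is weakly supported, and another limit remains possible.

The expected step is an at least 5.0-fold lower number from compound 3 to compound 4 (0.69 log units; beyond the scatter).

The estimate for compound 4 is 2000 nM, with an expected range of 400 nM to 9000 nM.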

Compound 4, half-maximal inhibitory concentration: 148 nM
Estimate against measurement, compound 4: 14-fold (1.13 log units) above; the whole stated range lies above it.
By their numbers in this assay, from the lowest: compound 4; then compound 2; then compound 1. At a limit, above all of these: compound 3.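

In this assay, the exchange of 1H-indazol-5-yl on the triple-bonded carbon gives an at least 67-fold lower number from compound 3 to compound 4 (1.82 log units; beyond the scatter), so this place in the series can carry a large change in the read-out. Among these compounds, the only earlier step, a 2.8-fold lower number from compound 1 to compound 2 (0.44 log units; beyond the scatter), came from a fluoro in place of hydrogen on an aromatic carbon and showed nothing about this place. The entry for compound 3 is a limit and not a number, so the true step may be larger than printed: the limit of > 10000 nM in this assay, at which 1 of the 4 values shown sits.

This single exchange does not separate the effect of the six-membered aromatic ring with 1 hetero atom from that of the rest of the entering group. From the compounds shown here alone, it also remains open whether an amine or a longer carbon chain on the entering group would keep the value of compound 4 at 148 nM.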